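Amide-to-urea exchange on the shared core: working notes

The compounds below may be only part of what the source reports. "The series", "measured", "known", "first", "only" and "open" are said of these compounds alone.

Two compounds built on the shared core of compound 1 `CN(C(=O)C(C)(C)C)c1ccc2[nH]c(-c3n[nH]c4ccccc34)cc2n1` have been measured in a functional assay on HL-60 cells (Homo sapiens) for antiproliferative activity, read by MTT assay, with a stated time of 72 h; on this read-out lower numbers stand for stronger inhibition and higher numbers for weaker inhibition. Compound 1 gives 4990 nM, the lowest of the two numbers. Compound 2 `COc1ccc(S(=O)(=O)N(C)c2ccc3[nH]c(-c4n[nH]c5ccccc45)cc3n2)c(OC)c1` gives 5180 nM, a value that sits within the scatter of the value for compound 1, so no order between the two can be read. Going by the values given here, no measured pair differs in one place only, so no measured step exists for the series yet.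

Compound 3 `COc1ccc(NC(=O)N(C)c2ccc3[nH]c(-c4n[nH]c5ccccc45)cc3n2)cc1` remains to be measured in this assay. It differs from compound 1 in one place: (4-methoxyphenyl)amino in place of tert-butyl on a carbonyl carbon. Among the compounds with values here, the two values known so far lie in the same region and come from compounds that differ from each other in more than one feature, so they say nothing about what this exchange alone does. Within the data shown here, with no measured step of this kind to lean on, the step this exchange brings in this assay is expected to stay within the scatter, direction open, and is estimated as a 1.2-fold lower number from compound 1 to compound 3 (0.10 log units; within the scatter). The expected value of compound 3 is 4000 nM, with a range from 1300 nM to 12000 nM.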

Compound 3, half-maximal inhibitory concentration: 7.9 nM
Compound 3: the middle estimate sits 510-fold (2.70 log units) above what was measured; the whole stated range lies above it.
By their numbers in this assay, from the lowest: compound 3; then compounds 1 and 2 (each within the scatter of the next).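

In this assay, going by these compounds alone, the carbonyl substituent on the shared core proves to be a position of very high sensitivity: (4-methoxyphenyl)amino in place of tert-butyl gives a 630-fold lower number from compound 1 to compound 3 (2.80 log units; beyond the scatter), the only measured step and a large one, which turns the amide of compound 1 into the urea of compound 3. The earlier values offered no one-place comparison and so gave no view of what this position can do. The exchange brings in an amino hydrogen, an aromatic ring and a methoxy group together, so the step belongs to the change as a whole and cannot be divided among these parts, and nothing available accounts for its size.

Still open, on these data alone, is whether the step needs the amino hydrogen or the aromatic ring: (4-methoxyphenyl)methyl on the same carbonyl carbon would keep the ring without that hydrogen, while tert-butylamino would keep the hydrogen without the ring. As far as these compounds go, the part played by the methoxy group is equally open, and plain phenylamino or (4-chlorophenyl)amino at this position would address it.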